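Urea series: replacing the aniline of compound 1

This account rests on a few compounds, and the source may have more. Where it says the series, first, only, none or still open, it means among the compounds named here.

Three compounds have numbers in a functional assay on NCI-H520 cells (Homo sapiens) for inhibition, read by MTT assay, with a stated time of 48 h, tested at 10 uM; on this read-out lower numbers stand for less inhibition and higher numbers for more inhibition at the one concentration tested (going by the name of the read-out). Compound 1 `COc1cc(NC(=O)Nc2cc(Nc3ccc(OC)c(C)c3)ncn2)cc(OC)c1` gives 13.5%, the lowest of the three. Compound 3 `COc1cc(Nc2cc(NC(=O)Nc3c(Cl)cccc3Cl)ncn2)cc(C(F)(F)F)c1` gives 23.1%, a number that sits within the scatter of compound 1, so the two cannot be ordered. Within the data shown here, compound 2 `COc1ccc(OC)c(Nc2cc(NC(=O)Nc3c(Cl)cccc3Cl)ncn2)c1` gives 74%, which lies beyond the scatter above compound 1 and is the only number in the set that clearly separates from it. Among the measured compounds shown here, compounds 2 and 3 both carry the same dichlorophenyl urea and differ from each other in the aniline only; compound 1 differs from both in the urea and in the aniline at once, so no single-change step between measured compounds is available.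

Compound 4 `COc1cc(NC(=O)Nc2cc(Nc3ccc(F)c(Cl)c3)ncn2)cc(OC)c1` keeps the urea of compound 1 and changes the aniline: 3-chloro-4-fluorophenyl in place of 4-methoxy-3-methylphenyl on a nitrogen on an aromatic ring. Nothing measured here isolates this change on its own. The aniline swaps between compounds 2 and 3 leave room for a visible move in this assay, though both of those compounds differ from compound 1 in a second place as well. A moderate rise from compound 1 is expected for compound 4, as the step of a number 11.5 percentage points higher from compound 1 to compound 4 (beyond the scatter), with wide uncertainty. Compound 4 is estimated at 25%, between 8% and 50%.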

Compound 4, a percentage reported as inhibition, at one concentration (the size of the read-out at that concentration, not a potency): 25.5%
The estimate for compound 4 lay 0.5 percentage points below the measured number, within the range that was stated.
By their numbers in this assay, from the lowest: compounds 1, 3 and 4 (each within the scatter of the next, the first and the last beyond it); then compound 2.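

In this assay, the series now has its first single-change step: with the urea of compound 1 held fixed, 3-chloro-4-fluorophenyl in place of 4-methoxy-3-methylphenyl on a nitrogen on an aromatic ring gives a number 12 percentage points higher from compound 1 to compound 4 (beyond the scatter). Among these compounds, this shows that the aniline position alone can move the number, which the earlier compounds could not show, as each pair among them that involved compound 1 differed in two places. The step is modest, and the two aryl groups differ in both of their substituents at once, so it cannot be assigned to the chlorine, the fluorine, or the loss of the methoxy or the methyl, and no measurement here bears on why the number moved.

Still open, on these data alone, is whether the same aniline swap carries over to the dichlorophenyl urea of compounds 2 and 3, or whether this step belongs to the urea of compound 1 alone. Also open, as far as these compounds go, is how this position responds to groups of a different kind on the aniline ring, such as a dimethylamino group or a carboxylic acid.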